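From chloro to bromo on the shared core

The source may report more compounds than this note shows. Statements on the series, on what has been measured and on what is new or still open speak of the compounds shown alone.

Compound 1 `C/C=C/C=C/C(=O)N(Cc1ccc(OC)c(O)c1)c1cc(OC)c(OC)c(OC)c1`: 180 nM
Compound 2 `COc1ccc(CN(C(=O)CCl)c2cc(OC)c(OC)c(OC)c2)cc1O`: 250 nM

In a functional assay on HCT-116 cells (Homo sapiens) for inhibition, read by MTT assay, with a stated time of 48 h (a higher number here means a weaker inhibitor, a lower number a stronger inhibitor), compound 2 gives 250 nM, which lies within the scatter of compound 1. Compound 3 `COc1ccc(CN(C(=O)CBr)c2cc(OC)c(OC)c(OC)c2)cc1O` differs from compound 2 by bromo in place of chloro on a saturated chain carbon bound to a carbonyl carbon. Going by the values given here, the only measured step, a 1.4-fold higher number from compound 1 to compound 2 (0.14 log units; within the scatter), exchanges a far larger group on a carbonyl carbon, yet stays within the scatter. Among the compounds with values here, no measured step exchanges chloro for bromo directly. The expected change is therefore none beyond the scatter: a 1.3-fold lower number from compound 2 to compound 3 (0.10 log units; within the scatter). For compound 3 the estimated value is 200 nM, with an expected range from 80 nM to 500 nM.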

Compound 3, half-maximal inhibitory concentration: 68 nM
Compound 3: the middle estimate sits 2.9-fold (0.47 log units) above what was measured; measured number outside the range, below it.
By their numbers in this assay, from the lowest: compound 3; then compounds 1 and 2 (each within the scatter of the next).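

At the saturated chain carbon bound to a carbonyl carbon, bromo in place of chloro, a swap of one heavy atom for one, moves the result beyond the scatter in this assay, with a 3.7-fold lower number from compound 2 to compound 3 (0.57 log units; beyond the scatter). Bromomethyl in place of penta-1,3-dien-1-yl also gives a change beyond the scatter, a 2.6-fold lower number from compound 1 to compound 3 (0.42 log units; beyond the scatter), so this position responds to what it carries, which the first pair did not show. Nothing available explains why this exchange matters. The compounds shown leave open how iodo or an amine on this same carbon would read, and whether the step holds on another core.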